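The source may report more compounds than this note shows. Statements on the series, on what has been measured and on what is new or still open speak of the compounds shown alone.

In a physicochemical assay for lipophilicity, using the shake flask method, in phosphate buffer, measured as octanol-water partition, with a stated time of 24 h, at pH 7.4 (a higher number here means a more lipophilic compound, a lower number a more polar compound), compound 1 `Cc1nn(-c2ccccc2F)c2c1CCS(=O)(=O)O2` gives 1.86 and compound 2 `O=S1(=O)CCc2c(C3CC3)nn(-c3ccccc3F)c2O1` gives 2.09, so these two stand within the scatter of each other. Compound 3 `Cc1cc(C2CS(=O)(=O)Oc3c2c(C2CC2)nn3-c2ccccc2F)ccc1Br` differs from compound 2 by 4-bromo-3-methylphenyl in place of hydrogen on a saturated ring carbon, a new aromatic ring with no hydrogen-bond donors or acceptors. Among the measured compounds shown here, the only measured step, a number 0.23 log units higher from compound 1 to compound 2 (within the scatter), is cyclopropyl in place of methyl on an aromatic carbon, so it offers little guide to a change of this size and place. A much larger rise is expected here, an estimated a number 2.21 log units higher from compound 2 to compound 3 (beyond the scatter). For compound 3 the expected value is 4.3, with an estimated range of 3.6 to 5.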

Compound 3, partition coefficient: 2.72
Estimate against measurement, compound 3: 1.58 log units above; the measured number lies below the stated range.
By their numbers in this assay, from the lowest: compounds 1 and 2 (each within the scatter of the next); then compound 3.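

In this assay, among the compounds shown here, 4-bromo-3-methylphenyl in place of hydrogen on the saturated ring carbon gives a number 0.63 log units higher from compound 2 to compound 3 (beyond the scatter) and so makes the first step here that stands clear of the scatter. It shows that this position, unlike the aromatic carbon changed earlier, can carry a whole new aromatic ring with a measurable but modest shift in the number. No measured evidence here accounts for the size of this step.

As far as these compounds go, how far the bromine and the methyl each contribute remains open. So does the effect of an amine or a carboxylic acid on the new ring.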